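Swapping pyridine attachment in vinyl sulfones acting on a transcription factor

The source may hold more compounds than are shown below. What is called first, only, known or untested is meant among the compounds shown, and "the series" means these compounds.

Measured compounds:
- compound 1, `COc1cccc(S(=O)(=O)/C=C/c2ccccn2)c1`: 2170 nM
- compound 2, `COc1ccc(S(=O)(=O)/C=C/c2ccccn2)cc1`: > 10000 nM
- compound 3, `COc1cccc(S(=O)(=O)/C=C/c2cccnc2)c1`: 6290 nM

Three vinyl sulfones were tested in an assay on U2OS cells for activation of nuclear factor erythroid 2-related factor 2 (Homo sapiens), read by chemiluminescence, with a stated time of 6 h; a lower number here means that less compound is needed, a higher number that more compound is needed for the effect. Compound 1 `COc1cccc(S(=O)(=O)/C=C/c2ccccn2)c1` gives 2170 nM in this assay. Compound 3 `COc1cccc(S(=O)(=O)/C=C/c2cccnc2)c1` gives 6290 nM. These two share a core and differ only by pyridin-3-yl in place of pyridin-2-yl on a double-bonded chain carbon bound to a double-bonded chain carbon; that change produced a 2.9-fold higher number from compound 1 to compound 3 (0.46 log units; beyond the scatter), a modest weakening. Compound 2 `COc1ccc(S(=O)(=O)/C=C/c2ccccn2)cc1` reached only the assay limit, > 10000 nM, so for compound 2 only a range is known, as the shown limit makes clear (the limit of > 10000 nM in this assay, at which 1 of the 3 values shown sits). How the core of compound 2 differs from that of compound 1 is not broken down here.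

Compound 4 `COc1ccc(S(=O)(=O)/C=C/c2cccnc2)cc1` has not yet been measured. Among the compounds with values here, it stands to compound 2 as compound 3 stands to compound 1: the change is pyridin-3-yl in place of pyridin-2-yl on a double-bonded chain carbon bound to a double-bonded chain carbon, the same kind of change, made at the same place, as the one from compound 1 to compound 3. If the same-sized weakening applies, compound 4 is expected to sit beyond the limit already reached by compound 2. The step from compound 2 to compound 4 is therefore estimated as a step that the limit leaves unreadable from compound 2 to compound 4, resting on the measured weakening seen in a 2.9-fold higher number from compound 1 to compound 3 (0.46 log units; beyond the scatter). Compound 4 is thus expected near 30000 nM, most likely between 10000 nM and 100000 nM, with a strong chance that the assay again returns only a limit.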

Compound 4, half-maximal effective concentration: > 10000 nM
Compound 4 was reported as a limit; the forecaster's own chance of this, stated with the estimate: 85%; the middle value does not contradict the limit.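

In this assay compound 4 gives > 10000 nM, which is a limit of the assay and not a number. Compound 2 sits at the same limit, so the size of the swap from pyridin-2-yl to pyridin-3-yl between compound 2 and compound 4 cannot be read: the limit of > 10000 nM in this assay, at which 2 of the 4 values shown sit.

From the compounds shown here alone, what stays open is how much compound each of the two really needs, and whether the swap changes them as it changed compound 1 and compound 3.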